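The source may hold more compounds than are shown below. What is called first, only, known or untested is meant among the compounds shown, and "the series" means these compounds.

Compound 1 `O=C(O)c1cc(-n2c(-c3ccc(F)cc3)cc3c2CCCC3)ccc1O` gives in a functional assay on the whole organism (strain Wistar) for inhibition, with Rattus norvegicus as the target, read by paw edema, with stated times of 30 min and 3 h, at a dose of 200 mg/kg by the oral route (on this read-out lower numbers stand for less inhibition and higher numbers for more inhibition at the one dose given (going by the name of the read-out)), a value that is a limit of the assay, >= 60%. Compound 2 `O=C(O)c1cc(-n2c(-c3ccc(Br)cc3)cc3c2CCCC3)ccc1O` gives 40%. Compound 3 `O=C(O)c1cc(-n2c(-c3ccc(Cl)cc3)cc3c2CCCC3)ccc1O` gives 40%.

Compound 3 thus stands level with compound 2, with no change at the digits printed from compound 2 to compound 3 (within the scatter), while both sit under compound 1, shown by a number at least 20 percentage points lower from compound 1 to compound 3 (beyond the scatter) and a number at least 20 percentage points lower from compound 1 to compound 2 (beyond the scatter). For the measured compounds named here, only one value sits at the limit of >= 60% in this assay, at which 1 of the 3 values shown sits. Compound 4 `N#Cc1ccc(-c2cc3c(n2-c2ccc(O)c(C(=O)O)c2)CCCC3)cc1` differs from compound 3 by cyano in place of chloro on an aromatic carbon. Going by the values given here, no measured step exchanges a halogen for cyano; the steps from fluoro to chloro and to bromo ran lower, and chloro against bromo did not move the read-out. Among the compounds with values here, the cyano case has no direct precedent, so compound 4 is expected to show a step of about no change at the digits printed from compound 3 to compound 4 (within the scatter). Compound 4 is estimated at 40%, from 20% to 60%.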

Compound 4, a percentage reported as inhibition, in the whole organism at one dose (the size of the read-out at that dose, not a potency): 0%
Estimate against measurement, compound 4: 40 percentage points above; measured number below the stated range.
By their numbers in this assay, from the lowest: compound 4; then compounds 2 and 3 (each within the scatter of the next). At a limit, above all of these: compound 1.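

At this place on the aromatic ring, para to a large group, the read-out of this assay does not treat cyano as it treats the halogens: cyano in place of chloro gives a number 40 percentage points lower from compound 3 to compound 4 (beyond the scatter), and cyano in place of bromo gives a number 40 percentage points lower from compound 2 to compound 4 (beyond the scatter). For the compounds shown here, compound 4 thus shows that this position can lose the whole effect at this dose, which no halogen step showed. Compound 1 carries a limit, and its step, a number at least 60 percentage points lower from compound 1 to compound 4 (beyond the scatter), is a bound only: the limit of >= 60% in this assay, at which 1 of the 4 values shown sits.

As far as these compounds go, whether an amide, a methoxy group or a trifluoromethyl group at this place would follow the halogens or the nitrile stays open.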